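Urea series: aryl swap on the saturated ring carbon

The source may report more compounds than this note shows. Statements on the series, on what has been measured and on what is new or still open speak of the compounds shown alone.

In an assay on microsomes for inhibition of acyl-CoA:cholesterol acyltransferase (Oryctolagus cuniculus) (on this read-out higher numbers stand for weaker inhibition and lower numbers for stronger inhibition), compound 1 `CC(C)c1cccc(C(C)C)c1NC(=O)NCC1(c2ccc(C(C)(C)C)cc2)CCCC1` gives 63 nM. Compound 2 `CC(C)c1cccc(C(C)C)c1NC(=O)NCC1(c2cccc(OCc3ccccc3)c2)CCCC1` gives 30 nM in this assay. Compound 1 thus has the highest of the two numbers; compound 2 sits at a lower number, and that gap is beyond the scatter. Going by the values given here, no pair of measured compounds differs in a single place, so the weight of any one change is not yet known from measurement.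

Compound 3 `CC(C)c1cccc(C(C)C)c1NC(=O)NCC1(c2ccccc2C(F)(F)F)CCCC1` is not yet measured. It differs from compound 1 in one place: 2-(trifluoromethyl)phenyl in place of 4-(tert-butyl)phenyl on a saturated ring carbon. The group leaving and the group entering each carry one six-membered aromatic ring of carbon only, with no hydrogen-bond donors or acceptors, on the same saturated ring carbon. Among the compounds with values here, no comparable step has been measured. The expectation is a modest step toward weaker inhibition, of a size near the edge of the scatter, a 1.7-fold higher number from compound 1 to compound 3 (0.24 log units; within the scatter). Compound 3 is estimated at 110 nM in this assay, with a range from 30 nM to 400 nM.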

Compound 3, half-maximal inhibitory concentration: 18 nM
Beside the measured number, compound 3's estimate is 6.1-fold (0.79 log units) above it; the measured number lies below the stated range.
By their numbers in this assay, from the lowest: compounds 3 and 2 (each within the scatter of the next); then compound 1.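

The swap of 4-(tert-butyl)phenyl for 2-(trifluoromethyl)phenyl on a saturated ring carbon gives a 3.5-fold lower number from compound 1 to compound 3 (0.54 log units; beyond the scatter) in this assay. Going by these compounds alone, this is the first single-place step, and it shows that the number responds to which aryl group this carbon carries. The two groups match in heavy atoms, in their one six-membered aromatic ring of carbon only and in hydrogen-bond donors and acceptors, so those counts do not account for the step, and no measurement at hand bears on its origin.

Open, from the compounds shown here alone, is how much of the step belongs to losing 4-(tert-butyl)phenyl and how much to gaining 2-(trifluoromethyl)phenyl. Also open, going by these compounds, is what an unsubstituted phenyl, a pyridine ring or an aryl group carrying an amine would do on this carbon.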